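Amide in Place of Benzyl on the Ring Nitrogen

A few compounds are considered here, and "the series" means these few. Any claim that something is new, unique, unknown or untested is made for them only; others in the source may bear on it.

compound 1 `CC(C)(C)c1cc(NC(=O)[C@@H]2CCCCN2Cc2ccc(Cl)cc2)no1` — 0.15 h
compound 2 `CC(C)(C)c1cc(NC(=O)[C@@H]2CCCCN2CC2CCOCC2)no1` — 0.183 h
compound 3 `CC(C)(C)c1cc(NC(=O)[C@@H]2CCCCN2C(=O)C2CCCCC2)no1` — 0.483 h

In an ADME assay (liver) for metabolic stability, with Liver microsome (Homo sapiens) as the target, read by LC-MS, using microsomes and NADPH, tested at 1 uM (a higher number here means that the compound lasts longer, a lower number that the compound disappears faster), compound 1 gives the lowest of the three numbers; compound 2 lies within the scatter of it (a 1.2-fold higher number from compound 1 to compound 2 (0.09 log units; within the scatter)), while compound 3 lies beyond it (a 3.2-fold higher number from compound 1 to compound 3 (0.51 log units; beyond the scatter)). Compound 4 `CC(C)(C)c1cc(NC(=O)[C@@H]2CCCCN2C(=O)CC2CCOCC2)no1` differs from compound 1 by ((oxan-4-yl)methyl)carbonyl in place of 4-chlorobenzyl on an amine nitrogen in a ring. The step that bears most on this change is a 3.2-fold higher number from compound 1 to compound 3 (0.51 log units; beyond the scatter), which likewise sets a carbonyl-bearing group on an amine nitrogen in a ring, and a 2.6-fold higher number from compound 2 to compound 3 (0.42 log units; beyond the scatter) points the same way. Compound 4 is therefore expected to show a modest rise, a 2.7-fold higher number from compound 1 to compound 4 (0.43 log units; beyond the scatter). The estimate for compound 4 is 0.4 h, with a range from 0.2 h to 0.9 h.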

Compound 4, half-life: 1.83 h
Compound 4: the middle estimate sits 4.6-fold (0.66 log units) below what was measured; the measured number lies above the stated range.
By their numbers in this assay, from the lowest: compounds 1 and 2 (each within the scatter of the next); then compound 3; then compound 4.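

In this assay the carbonyl on the amine nitrogen in a ring does not settle the number alone, since (oxan-4-yl)methyl in place of cyclohexyl on the carbonyl carbon still gives (a 3.8-fold higher number from compound 3 to compound 4 (0.58 log units; beyond the scatter)). Placing a carbonyl on the (oxan-4-yl)methyl group gives (a 10-fold higher number from compound 2 to compound 4 (1.00 log units; beyond the scatter)), and the whole change gives (a 12-fold higher number from compound 1 to compound 4 (1.09 log units; beyond the scatter)), so the two parts together exceed what compound 3 showed. Going by these compounds, whether a longer chain before the oxan-4-yl ring, or an amine in it, would keep this gain remains open. Nothing shown here accounts for the size of these steps.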